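Dimethoxyphenyl in place of dichlorophenyl on the amide nitrogen

The source may report more compounds than this note shows. Statements on the series, on what has been measured and on what is new or still open speak of the compounds shown alone.

In a functional assay on K562 cells (Homo sapiens) for inhibition, read by MTT assay, with a stated time of 24 h (a lower number here means a stronger inhibitor, a higher number a weaker inhibitor), three compounds have been measured:
compound 1 `O=C(Cn1c(=O)c(/C=C\c2ccncc2)nc2ccccc21)Nc1ccccc1` gives 55500 nM.
compound 2 `Cc1ccccc1NC(=O)Cn1c(=O)c(/C=C\c2ccncc2)nc2ccccc21` sits at a limit of this assay, > 100000 nM.
compound 3 `O=C(Cn1c(=O)c(/C=C\c2ccncc2)nc2ccccc21)Nc1ccc(Cl)c(Cl)c1` sits at a limit of this assay, > 100000 nM.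

Compound 3 thus stands only at a limit, where two of the three values sit (the limit of > 100000 nM in this assay, at which 2 of the 3 values shown sit). The next compound, compound 4 `COc1ccc(NC(=O)Cn2c(=O)c(/C=C\c3ccncc3)nc3ccccc32)cc1OC`, differs from it by 3,4-dimethoxyphenyl in place of 3,4-dichlorophenyl on an amide-type nitrogen. For the measured compounds named here, two measured steps touch this amide-nitrogen aryl group: an at least 1.8-fold higher number from compound 1 to compound 2 (0.25 log units; that floor lies within the scatter) and an at least 1.8-fold higher number from compound 1 to compound 3 (0.25 log units; that floor lies within the scatter); the third, a step that the two limits leave unreadable from compound 2 to compound 3, runs between two limits. Both readable steps moved toward weaker inhibition, and compound 4 is therefore expected to stay near the limit, with an at least 1.1-fold lower number from compound 3 to compound 4 (0.04 log units; that floor lies within the scatter) expected to be no readable step. The estimate for compound 4 is 90000 nM, within 30000 nM to 300000 nM.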

Compound 4, half-maximal inhibitory concentration: 55200 nM
For compound 4 the middle estimate is 1.6-fold (0.21 log units) above the measured one; the range from low to high includes it.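

In this assay, the 3,4-dimethoxyphenyl group on the amide-type nitrogen gives a measured number rather than a limit, so a substituted aryl here need not end at a limit as in compound 2 and compound 3. Against the unsubstituted phenyl, the change amounts to a 1.0-fold lower number from compound 1 to compound 4 (0.00 log units; within the scatter). The other two steps, an at least 1.8-fold lower number from compound 3 to compound 4 (0.25 log units; that floor lies within the scatter) and an at least 1.8-fold lower number from compound 2 to compound 4 (0.25 log units; that floor lies within the scatter), are only floors set by a limit: the limit of > 100000 nM in this assay, at which 2 of the 4 values shown sit.

The compounds shown leave open whether a single methoxy group, an amine or a carboxylic acid on this aryl ring would also give a measured number. How far compound 2 and compound 3 truly lie from compound 4 also stays unread.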